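Cytotoxicity series: methoxy step from compound 2 to compound 4

The compounds below may be only part of what the source reports. "The series", "measured", "known", "first", "only" and "open" are said of these compounds alone.

Measured compounds:
compound 1 `O=C(/C=C1/SC(=O)NC1=O)Oc1ccccc1/C=N/NC(=O)c1ccncc1` — > 200 ug/mL
compound 2 `O=C(CC1SC(=O)NC1=O)Oc1ccc(/C=N/NC(=O)c2ccncc2)cc1` — 91.7 ug/mL
compound 3 `O=C(/C=C1/SC(=O)NC1=O)Oc1cccc(/C=N\NC(=O)c2ccncc2)c1` — 143 ug/mL

In an ADME assay on Vero cells (Chlorocebus sabaeus) for cytotoxicity, read by MTT assay, with a stated time of 24 h (a lower number here means a stronger inhibitor, a higher number a weaker inhibitor), compound 1 gives > 200 ug/mL, which is a limit of the assay and not a number (the limit of > 200 ug/mL in this assay, at which 1 of the 3 values shown sits). Compound 2 gives 91.7 ug/mL, the lowest of the two numbers shown. Compound 3, with 143 ug/mL, sits within the scatter of compound 2, so no order between the two can be read. Compound 4 `COc1cc(/C=N/NC(=O)c2ccncc2)ccc1OC(=O)CC1SC(=O)NC1=O` is not yet measured; it differs from compound 2 by methoxy in place of hydrogen on an aromatic carbon. Within the data shown here, no step between measured compounds shows the weight of such a change. The step from compound 2 to compound 4 is expected to be small, within the scatter, with no clear direction, as a 1.1-fold higher number from compound 2 to compound 4 (0.04 log units; within the scatter). Compound 4 is therefore expected near 100 ug/mL, between 50 ug/mL and 200 ug/mL.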

Compound 4, half-maximal inhibitory concentration: 203 ug/mL
Compound 4: middle estimate off by 2.0-fold (0.31 log units), on the low side; the measured number lies above the stated range.
By their numbers in this assay, from the lowest: compounds 2, 3 and 4 (each within the scatter of the next, the first and the last beyond it).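

Among these compounds, the first one-place step in this assay is a 2.2-fold higher number from compound 2 to compound 4 (0.35 log units; beyond the scatter) and comes from methoxy in place of hydrogen on an aromatic carbon, ortho to a large group and meta to a large group. This carbon is therefore not silent to substitution, though the step is modest. Compound 1 gives a limit and not a number: the limit of > 200 ug/mL in this assay, at which 1 of the 4 values shown sits.

A single step leaves open whether ethoxy, hydroxyl or an amine on this carbon would move the number the same way. Going by these compounds, whether methoxy has the same weight on the other aromatic carbons also stays open.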